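Bromo on compound 3: what size of step to expect

The source may report more compounds than this note shows. Statements on the series, on what has been measured and on what is new or still open speak of the compounds shown alone.

Measured in a functional assay on HT-29 cells (Homo sapiens); a higher number here means a weaker inhibitor of growth, a lower number a stronger inhibitor of growth:
- compound 1 `N#Cc1ccc(/C=C/S(=O)(=O)Cc2ccc(Nc3ncnc4ccccc34)cc2)cc1`: > 100000 nM, a limit of the assay
- compound 2 `O=S(=O)(/C=C/c1ccc(Cl)cc1Cl)Cc1ccc(Nc2ncnc3ccccc23)cc1`: 24000 nM
- compound 3 `O=S(=O)(/C=C/c1ccc(O)cc1)Cc1ccc(Nc2ncnc3ccccc23)cc1`: 2000 nM

Compound 3 has the lowest number of the three, and compound 2 is its nearest neighbour, as a 12-fold lower number from compound 2 to compound 3 (1.08 log units; beyond the scatter) shows. Compound 4 `O=S(=O)(/C=C/c1ccc(O)cc1)Cc1ccc(Nc2ncnc3ccc(Br)cc23)cc1` carries bromo in place of hydrogen on an aromatic carbon, part of a fused or bridged system of two rings (bromo in place of hydrogen on an aromatic carbon). The measured steps, an at least 4.1-fold lower number from compound 1 to compound 2 (0.61 log units; beyond the scatter), an at least 50-fold lower number from compound 1 to compound 3 (1.69 log units; beyond the scatter) and a 12-fold lower number from compound 2 to compound 3 (1.08 log units; beyond the scatter), all lie beyond the scatter, but none of them changes that ring. They therefore give no size for this change, and no step beyond the scatter is expected in this assay. The expected step is a 1.3-fold higher number from compound 3 to compound 4 (0.10 log units; within the scatter). The estimate for compound 4 is 2500 nM, with an expected range from 600 nM to 10000 nM.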

Compound 4, concentration for 50% growth inhibition: 9000 nM
Compound 4: the middle estimate sits 3.6-fold (0.56 log units) below what was measured; low and high end bracket the measured number.
By their numbers in this assay, from the lowest: compound 3; then compound 4; then compound 2. At a limit, above all of these: compound 1.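

In this assay, among these compounds, the ring that none of the earlier steps touched proves responsive: bromo in place of hydrogen on an aromatic carbon gives a 4.5-fold higher number from compound 3 to compound 4 (0.65 log units; beyond the scatter) and so weakens growth inhibition. Among the compounds shown here, this is the first size for a change at this position, and its direction is towards a higher number. Nothing on hand accounts for the size of this step. The compounds shown leave open how fluoro, methoxy or an amine would act at this position, and whether bromo has the same effect with the 2,4-dichlorophenyl group of compound 2.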